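Heteroaryl swap on the trifluoromethylphenyl ring: solubility notes

The compounds below may be only part of what the source reports. "The series", "measured", "known", "first", "only" and "open" are said of these compounds alone.

Measured so far:
compound 1, `O=C1OCCN1c1cc(C(F)(F)F)ccc1[C@H]1CCOc2cc(S(=O)(=O)Nc3nccs3)ccc21`: 295000 nM
compound 2, `Cn1nccc1-c1cc(C(F)(F)F)ccc1[C@H]1CCOc2cc(S(=O)(=O)Nc3nccs3)ccc21`: 83000 nM
compound 3, `Cc1nc(-c2cc(C(F)(F)F)ccc2[C@H]2CCOc3cc(S(=O)(=O)Nc4nccs4)ccc32)co1`: 61000 nM

In a physicochemical assay for solubility (on this read-out higher numbers stand for higher solubility and lower numbers for lower solubility), compound 3 stands lowest of the three: a 1.4-fold lower number from compound 2 to compound 3 (0.13 log units; within the scatter), whereas a 4.8-fold lower number from compound 1 to compound 3 (0.68 log units; beyond the scatter).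

Compound 4, `O=S(=O)(Nc1nccs1)c1ccc2c(c1)OCC[C@@H]2c1ccc(C(F)(F)F)cc1-c1nccs1`, differs from compound 3 in one place: 1,3-thiazol-2-yl in place of 2-methyl-1,3-oxazol-4-yl on an aromatic carbon. Going by the values given here, the step that bears on this is the only other exchange of one five-membered aromatic ring for another, a 1.4-fold lower number from compound 2 to compound 3 (0.13 log units; within the scatter). The steps of a 3.6-fold lower number from compound 1 to compound 2 (0.55 log units; beyond the scatter) and a 4.8-fold lower number from compound 1 to compound 3 (0.68 log units; beyond the scatter) start from the 2-oxo-1,3-oxazolidin-3-yl compound and say less about a ring-for-ring swap. For compound 4 no step beyond the scatter is therefore expected, a 1.2-fold lower number from compound 3 to compound 4 (0.09 log units; within the scatter). Compound 4 is estimated at 50000 nM, with a range of 20000 nM to 120000 nM.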

Compound 4, solubility: 15000 nM
Compound 4: middle estimate off by 3.3-fold (0.52 log units), on the high side; the measured number lies below the stated range.
By their numbers in this assay, from the lowest: compound 4; then compounds 3 and 2 (each within the scatter of the next); then compound 1.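

At this aromatic carbon, an exchange of one five-membered aromatic ring for another can matter in this assay: 1,3-thiazol-2-yl gives a 4.1-fold lower number from compound 3 to compound 4 (0.61 log units; beyond the scatter) in place of 2-methyl-1,3-oxazol-4-yl. The same group gives a 5.5-fold lower number from compound 2 to compound 4 (0.74 log units; beyond the scatter) in place of 1-methyl-1H-pyrazol-5-yl and a 20-fold lower number from compound 1 to compound 4 (1.29 log units; beyond the scatter) in place of 2-oxo-1,3-oxazolidin-3-yl, which leaves compound 4 lowest of the four. No measurement at hand accounts for these steps.

Open, going by these compounds, is whether an amine or a carboxylic acid at this carbon would reach the number of compound 1 295000 nM or stay nearer compound 4.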